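Swapping the aryl on the triazole: cytotoxicity of compound 4

This account rests on a few compounds, and the source may have more. Where it says the series, first, only, none or still open, it means among the compounds named here.

Measured so far:
- compound 1 `Cc1cccc(-n2cc(-c3ccccc3NS(=O)(=O)c3c[nH]c(=O)[nH]c3=O)nn2)c1`: in an ADME assay on L02 cells (Homo sapiens) for cytotoxicity, read by MTT assay, with a stated time of 24 h (a lower number here means that less compound is tolerated, a higher number that more compound is tolerated), compound 1 gives 21900 nM
- compound 2 `O=c1[nH]cc(S(=O)(=O)Nc2ccccc2-c2cn(-c3ccc(Cl)cc3)nn2)c(=O)[nH]1`: in this assay compound 2 gives 16800 nM
- compound 3 `Cc1ccccc1-n1cc(-c2cccc(NS(=O)(=O)c3c[nH]c(=O)[nH]c3=O)c2)nn1`: in this assay compound 3 gives 15300 nM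

Compound 3 gives the lowest of the three numbers, but its gaps to compound 2 and to compound 1 are both within the usual scatter of this assay, so the three compounds are not truly separated by these measurements.

Compound 4 `O=c1[nH]cc(S(=O)(=O)Nc2cccc(-c3cn(-c4ccc(Cl)cc4)nn3)c2)c(=O)[nH]1` is compound 3 with one change: 4-chlorophenyl in place of 2-methylphenyl on an aromatic nitrogen. The nearest guide is the step from compound 1 to compound 2, where a 4-chlorophenyl also replaced a methyl-bearing phenyl on the same aromatic nitrogen, and gave a 1.3-fold lower number from compound 1 to compound 2 (0.12 log units; within the scatter). That step stayed inside the scatter, and the change here is of the same kind, so no step beyond the scatter is expected in this assay from compound 3 to compound 4, with at most a slight drift downward, a 1.1-fold lower number from compound 3 to compound 4 (0.05 log units; within the scatter). Compound 4 is therefore estimated at 13500 nM, within a range of 7000 nM to 26000 nM.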

Compound 4, half-maximal cytotoxic concentration: 9860 nM
Beside the measured number, compound 4's estimate is 1.4-fold (0.14 log units) above it, within the range that was stated.
By their numbers in this assay, from the lowest: compounds 4, 3, 2 and 1 (each within the scatter of the next, the first and the last beyond it).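

Placed on the aromatic nitrogen of the core of compound 3, the exchange of 2-methylphenyl for 4-chlorophenyl does not separate the two compounds (a 1.6-fold lower number from compound 3 to compound 4 (0.19 log units; within the scatter)). This gives a second case, in a different core, alongside the exchange of 3-methylphenyl for 4-chlorophenyl (a 1.3-fold lower number from compound 1 to compound 2 (0.12 log units; within the scatter)), so in both pairs shown, this kind of swap stays within the scatter of this assay. Nothing available here accounts for the size of either step.

All four compounds carry a substituted phenyl on this nitrogen, so these data cannot show how much the number can move at this position. As far as these compounds go, it remains open whether a phenyl bearing an amine or a carboxylic acid, or a longer carbon chain in place of the phenyl, would produce a step beyond the scatter in this assay.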